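A few compounds are considered here, and "the series" means these few. Any claim that something is new, unique, unknown or untested is made for them only; others in the source may bear on it.

Three compounds have been measured in a functional assay on MIA PaCa-2 cells (Homo sapiens) for inhibition, read by MTT assay, with a stated time of 72 h; a higher number here means a weaker inhibitor of growth, a lower number a stronger inhibitor of growth:

Compound 1 `CC(C)(C)c1ccc(CNCCCNS(=O)(=O)c2cc(C(F)(F)F)cc(C(F)(F)F)c2)cc1`, which gives 2300 nM
Compound 2 `O=S(=O)(NCCCCCCNCc1ccc(Br)cc1)c1cc(Cl)cc(Cl)c1`, which gives 12000 nM
Compound 3 `O=S(=O)(NCCCCCCNCc1ccc(Br)cc1)c1cccc(C(F)(F)F)c1`, which gives 5970 nM

Compound 1 stands lowest of these three numbers. Its nearest neighbour is compound 3, whose number is higher by a margin beyond the scatter; compound 2 lies furthest away, again beyond the scatter. For the measured compounds named here, compounds 2 and 3 differ from compound 1 in more than one place, so no single step can be drawn between them.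

Compound 4 `O=S(=O)(NCCCNCc1cccc2ccccc12)c1cc(C(F)(F)F)cc(C(F)(F)F)c1` keeps the sulfonamide and the chain of compound 1 and differs in one place: naphthalen-1-yl in place of 4-(tert-butyl)phenyl on a saturated chain carbon bound to an amine nitrogen. Going by the values given here, no pair of measured compounds shows this change, so its size is not known from the data. The group leaving and the group entering carry the same count of heavy atoms and the same absence of donors and acceptors, which gives no ground to expect a step beyond the scatter in either direction in this assay.

Compound 4 is therefore expected to come in at 2800 nM, within 1000 nM to 8000 nM, an expected step of a 1.2-fold higher number from compound 1 to compound 4 (0.09 log units; within the scatter).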

Compound 4, concentration for 50% growth inhibition: 2800 nM
Compound 4: middle estimate and measured number agree at the digits printed; the range from low to high includes it.
By their numbers in this assay, from the lowest: compounds 1 and 4 (each within the scatter of the next); then compounds 3 and 2 (each within the scatter of the next).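

For the compounds shown here, this is the first step that can be read at this position: in this assay, naphthalen-1-yl in place of 4-(tert-butyl)phenyl on a saturated chain carbon bound to an amine nitrogen gives a 1.2-fold higher number from compound 1 to compound 4 (0.09 log units; within the scatter). With the sulfonamide and the chain held fixed, going from one six-membered aromatic ring carrying a tert-butyl group to two such rings with the same count of heavy atoms leaves the number within the scatter. Nothing on hand explains why these two groups read alike.

The compounds shown leave open whether a single step in the other direction, to a smaller group such as a plain phenyl, or to a ring holding nitrogen such as pyridin-3-yl, would move the number beyond the scatter. They also leave open whether a cyclohexyl group, with no aromatic ring at all, would read like these two.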